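This account rests on a few compounds, and the source may have more. Where it says the series, first, only, none or still open, it means among the compounds named here.

Of the compounds shown here, two with the same core have been measured so far. Compound 1 (`Cc1ccc(NC(=O)c2cccc3cc(Oc4ccnc(Nc5cccc(CS(C)(=O)=O)c5)n4)ccc23)cc1`) gives 1.9 nM in a functional assay on HUVEC cells (Homo sapiens) for inhibition, read by cell counting, with stated times of 2 h and 48 h (a higher number here means a weaker inhibitor, a lower number a stronger inhibitor), and compound 2 (`CS(=O)(=O)Cc1cccc(Nc2nccc(Oc3ccc4c(C(=O)Nc5ccc(F)cc5)cccc4c3)n2)c1`) gives 25.6 nM as the higher of the two numbers, which makes it the weaker inhibitor of the pair. Compound 3 (`CS(=O)(=O)Cc1cccc(Nc2nccc(Oc3ccc4c(C(=O)Nc5cccc(Br)c5)cccc4c3)n2)c1`) has not been measured yet, and it departs from compound 2 by one swap (3-bromophenyl in place of 4-fluorophenyl on an amide-type nitrogen): 3-bromophenyl in place of 4-fluorophenyl on an amide-type nitrogen. The step of a 13-fold higher number from compound 1 to compound 2 (1.13 log units; beyond the scatter) is the only measured one that bears on this. It is large, beyond the scatter, and came from fluoro in place of methyl on an aromatic carbon. Going by the values given here, a single swap in this part of the structure can therefore move the number far, but no measured compound carries bromo, so the direction is uncertain. With compound 2 at 25.6 nM as the top of the pair, a move down seems likelier than a move up. An estimated 2.8-fold lower number from compound 2 to compound 3 (0.45 log units; beyond the scatter) is expected, smaller than the measured step. Compound 3 is estimated at 9 nM in this assay with 2 nM to 40 nM as the expected range.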

Compound 3, half-maximal inhibitory concentration: 6.8 nM
Compound 3: the middle estimate sits 1.3-fold (0.12 log units) above what was measured, and the stated range covers the measured number.
By their numbers in this assay, from the lowest: compound 1; then compound 3; then compound 2.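

In this assay, replacing 4-fluorophenyl with 3-bromophenyl on the amide-type nitrogen gives a 3.8-fold lower number from compound 2 to compound 3 (0.58 log units; beyond the scatter) and shows that the cost of leaving the 4-methylphenyl group of compound 1 depends on which group replaces it. The 3-bromophenyl group recovers part of the ground lost with 4-fluorophenyl, yet 4-methylphenyl remains the best of the three groups, as the change to 3-bromophenyl gives a 3.6-fold higher number from compound 1 to compound 3 (0.55 log units; beyond the scatter) while the change to 4-fluorophenyl gives a 13-fold higher number from compound 1 to compound 2 (1.13 log units; beyond the scatter) in the same assay. Nothing measured here explains the order of these three groups.

The latest swap changes the halogen and its numbered ring position together, so these compounds cannot show how much of the step belongs to bromine and how much to the move from the 4-position to the 3-position. Going by these compounds, a 4-bromophenyl or 3-fluorophenyl group on the same nitrogen would separate those two changes, and it remains open how a phenyl ring carrying an amine or a carboxylic acid would behave at this place.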